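Lipophilicity notes: anilino replacement on the shared core

A few compounds are considered here, and "the series" means these few. Any claim that something is new, unique, unknown or untested is made for them only; others in the source may bear on it.

Measured compounds:
- compound 1, `C[C@@H]1CC(=O)N(c2cnc(NCc3c(F)ccc4c3CCO4)n3cnnc23)C1`: 1.8
- compound 2, `CN(C)Cc1ccc2c(c1)CN(c1cnc(NCc3c(F)ccc4c3CCO4)n3cnnc13)C2=O`: 1.6

In a physicochemical assay for lipophilicity, using the shake flask method, in phosphate buffer, measured as octanol-water partition, with a stated time of 30 min, at pH 7.4 (a higher number here means a more lipophilic compound, a lower number a more polar compound), compound 1 gives 1.8. Compound 2 gives 1.6 in this assay, and the two numbers lie within the usual scatter of each other, so no order between compound 1 and compound 2 can be read from them.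

Compound 3, `Fc1ccc2c(c1CNc1ncc(Nc3ccccc3)c3nncn13)CCO2`, has not been measured in this assay. It differs from compound 1 in one place: anilino in place of 4-methyl-2-oxopyrrolidin-1-yl on an aromatic carbon

Going by the values given here, no measured pair shares this change, so its effect cannot be read from the data. The step from a number 1.00 log units higher from compound 1 to compound 3 (beyond the scatter) is an expectation only, and it is expected to go upward, beyond the scatter. On this basis compound 3 is estimated at 2.8 in this assay, with a range from 2.2 to 3.4.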

Compound 3, distribution coefficient: 3.3
Compound 3: middle estimate off by 0.50 log units, on the low side, within the range that was stated.
By their numbers in this assay, from the lowest: compounds 2 and 1 (each within the scatter of the next); then compound 3.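

In this assay, anilino in place of 4-methyl-2-oxopyrrolidin-1-yl on this aromatic carbon gives a number 1.50 log units higher from compound 1 to compound 3 (beyond the scatter), a large step. Going by these compounds alone, the values of compound 1 and compound 2 lie within the scatter of each other and gave no sign that the group at this position could move the number so far; this step shows that it can, with the same heavy-atom count in the leaving and entering groups. Nothing measured here accounts for the size of the step.

The change swaps a non-aromatic ring with a carbonyl for a carbon-only aromatic ring and adds a hydrogen-bond donor, and these two differences cannot be told apart from one pair. A phenyl group or an N-methylanilino group on the same carbon would separate them.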